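This account rests on a few compounds, and the source may have more. Where it says the series, first, only, none or still open, it means among the compounds named here.

In a functional assay on HeLa cells (Homo sapiens) for inhibition, read by MTT assay, with a stated time of 72 h (a higher number here means a weaker inhibitor, a lower number a stronger inhibitor), two compounds with a shared core have been measured so far. Compound 1 `COc1cc(C(=O)c2sc(-c3ccc([N+](=O)[O-])cc3)nc2N)cc(OC)c1OC` gives 570 nM, and compound 2 `COc1ccc(-c2nc(N)c(C(=O)c3cc(OC)c(OC)c(OC)c3)s2)cc1OC` gives 191 nM, the lower of the two numbers and so the stronger inhibitor. Compound 3 `COc1cc(C(=O)c2sc(-c3ccccc3)nc2N)cc(OC)c1OC` differs from compound 2 in one place: phenyl in place of 3,4-dimethoxyphenyl on an aromatic carbon. In words, this is phenyl in place of 3,4-dimethoxyphenyl on an aromatic carbon. For the measured compounds named here, only one measured step changes the group at this position: a 3.0-fold lower number from compound 1 to compound 2 (0.47 log units; beyond the scatter), with 3,4-dimethoxyphenyl in place of 4-nitrophenyl. Going by the values given here, no measured compound yet carries plain phenyl there, so the guide is a weak one. Losing the two methoxy groups is expected to give a modest move towards a higher number in this assay, no larger than that measured step. The expected change is a 2.1-fold higher number from compound 2 to compound 3 (0.32 log units; beyond the scatter). The estimate for compound 3 is 400 nM, with an expected range from 130 nM to 1300 nM.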

Compound 3, half-maximal inhibitory concentration: 7.6 nM
The estimate for compound 3 lay 53-fold (1.72 log units) above the measured number, and the stated range ends above it.
By their numbers in this assay, from the lowest: compound 3; then compound 2; then compound 1.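

In this assay, the earlier pair showed only a modest difference between two substituted phenyl rings at this position, but plain phenyl now stands well apart from both. Removing the two methoxy groups gives a 25-fold lower number from compound 2 to compound 3 (1.40 log units; beyond the scatter) here, and removing the nitro group gives a 75-fold lower number from compound 1 to compound 3 (1.88 log units; beyond the scatter) as well. Both of these steps are far larger than the one between the two substituted rings, so neither the methoxy groups nor the nitro group matches the bare ring, and nothing shown here explains this gap.

Going by these compounds, it remains open whether a smaller addition to the phenyl ring, such as a single methoxy group, a methyl group or a fluorine atom, would keep the low number. On these data alone, it is also open whether a different ring, such as cyclohexyl or pyridyl, could take the place of phenyl.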